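Chloro on the benzyl group of compound 3

The source may hold more compounds than are shown below. What is called first, only, known or untested is meant among the compounds shown, and "the series" means these compounds.

Values in a functional assay on RS4-11 cells (Homo sapiens) for inhibition, read by CCK-8 assay, with a stated time of 48 h (on this read-out higher numbers stand for weaker inhibition and lower numbers for stronger inhibition), so far
compound 1 `COc1ccc(S(=O)(=O)Oc2ccccc2/C=C(\C#N)C(=O)Nc2nnc(-c3cccs3)s2)cc1` gives 4750 nM
compound 2 `COc1ccc(S(=O)(=O)Nc2cccc(/C=C(\C#N)C(=O)Nc3nnc(-c4cccs4)s3)c2)cc1` gives > 20000 nM, a limit and not a number
compound 3 `COc1ccc(S(=O)(=O)Oc2ccccc2/C=C(\C#N)C(=O)Nc2nnc(Cc3ccccc3)s2)cc1` gives 1060 nM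

Compound 3 holds the lower of the two actual numbers, and the next step leads from it to compound 4 `COc1ccc(S(=O)(=O)Oc2ccccc2/C=C(\C#N)C(=O)Nc2nnc(Cc3ccc(Cl)cc3)s2)cc1`. The change is chloro in place of hydrogen on an aromatic carbon, giving 4-chlorobenzyl. Within the data shown here, no measured step makes this exchange. The closest is a 4.5-fold lower number from compound 1 to compound 3 (0.65 log units; beyond the scatter), a modest change at the same substituent, so only a small shift is expected in this assay, perhaps towards a lower number. The expected step is a 1.4-fold lower number from compound 3 to compound 4 (0.15 log units; within the scatter) overall. Compound 4 is estimated at 750 nM, within an expected range of 260 nM to 2200 nM for now.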

Compound 4, half-maximal inhibitory concentration: 1250 nM
The estimate for compound 4 lay 1.7-fold (0.22 log units) below the measured number, within the range that was stated.
By their numbers in this assay, from the lowest: compounds 3 and 4 (each within the scatter of the next); then compound 1. At a limit, above all of these: compound 2.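

In this assay, chloro at this place on the benzyl group gives no readable change (a 1.2-fold higher number from compound 3 to compound 4 (0.07 log units; within the scatter)), so the position accepts chloro without a shift beyond the scatter. The lower number relative to the thiophen-2-yl of compound 1 persists with 4-chlorobenzyl (a 3.8-fold lower number from compound 1 to compound 4 (0.58 log units; beyond the scatter)). No measurement at hand bears on this flat step.

Open, going by these compounds, is whether an amine or a carboxylic acid at the same place would also leave the number unchanged. Also open, on these data alone, is how a longer chain in place of benzyl would read.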